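Ring contraction of the amine ring on the amide nitrogen

The compounds below may be only part of what the source reports. "The series", "measured", "known", "first", "only" and "open" are said of these compounds alone.

Compound 1 `CCN(C(=O)c1ccccc1OCc1ccccc1)[C@@H]1CCC[C@H](NC(C)=O)C1`, in an assay on HEK293 cells for inhibition of transient receptor potential cation channel subfamily M member 8 (Homo sapiens), read by FLIPR and calcium flux; a higher number here means a weaker inhibitor, a lower number a stronger inhibitor: > 5000 nM
Compound 2 `CCN(C(=O)c1ccccc1OCc1ccccc1)[C@@H]1CC[C@H](N)C1`, in this assay: > 5000 nM
Compound 3 `CCN(C(=O)c1ccccc1OCc1ccccc1)C1CCCNC1`, in this assay: 4860 nM

The value of compound 1 in this assay is a limit of the assay, not a number. The value of compound 2 in this assay is likewise a limit. Compound 3 is the only one of the three with a measured number, and it sits just inside the limit of > 5000 nM in this assay, at which 2 of the 3 values shown sit, at which the other two rest. Going by the values given here, the one step measured in one place, an at least 1.0-fold lower number from compound 2 to compound 3 (0.01 log units; that floor lies within the scatter), lies within the scatter.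

Compound 4 `CCN(C(=O)c1ccccc1OCc1ccccc1)C1CCNC1` differs from compound 3 by pyrrolidin-3-yl in place of piperidin-3-yl on an amide-type nitrogen. Among the compounds with values here, no measured step bears directly on this change; the one step between neighbours, from compound 2 to compound 3, did not move the number beyond the scatter, and the shared core in every case gives a weak or unmeasurable value.

For compound 4 in this assay an estimate of 6000 nM is therefore expected, with a range from 2500 nM to 15000 nM. The expected step of a 1.2-fold higher number from compound 3 to compound 4 (0.09 log units; within the scatter) is within the scatter, and a limit rather than a number is about as likely as not.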

Compound 4, antagonist equilibrium constant: > 5000 nM
Compound 4 was reported as a limit; the forecaster's own chance of this, stated with the estimate: 55%; the middle value does not contradict the limit.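

In this assay compound 4 gives > 5000 nM, which is a limit of the assay and not a number. Pyrrolidin-3-yl in place of piperidin-3-yl on the amide-type nitrogen therefore yields only an at least 1.0-fold higher number from compound 3 to compound 4 (0.01 log units; that floor lies within the scatter), so its true size stays unknown and compound 3 still holds the only measured number. The step from compound 2 to compound 4 cannot be read, as both values are limits, and this position now offers little room for reading any change: the limit of > 5000 nM in this assay, at which 3 of the 4 values shown sit.

On these data alone, it remains open whether another group on this nitrogen, such as azetidin-3-yl or an open aminoethyl chain, would give a clearly lower number. As far as these compounds go, it is equally open whether a carboxylic acid or a longer ether chain elsewhere on the shared core would bring the values clear of the limit.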